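The compounds below may be only part of what the source reports. "The series", "measured", "known", "first", "only" and "open" are said of these compounds alone.

Compound 1 `O=C1CCC(N2C(=O)c3ccc(Nc4ccccc4)cc3C2=O)C(=O)N1` sits at the top of the three numbers gathered so far, giving 6% in an assay on FRT-Jurkat cells for inhibition of nuclear factor NF-kappa-B complex (Homo sapiens), read by flow cytometry, with a stated time of 24 h, tested at 10 uM; a lower number here means less inhibition, a higher number more inhibition at the concentration tested (going by the name of the read-out). Its two measured neighbours lie close: compound 2 `CN(c1ccccc1)c1ccc2c(c1)C(=O)N(C1CCC(=O)NC1=O)C2=O` gives -2% in this assay, and compound 3 `Cc1ccc(Nc2ccc3c(c2)C(=O)N(C2CCC(=O)NC2=O)C3=O)cc1` gives 5%. Both gaps, a number 8 percentage points lower from compound 1 to compound 2 (within the scatter) and a number 1 percentage points lower from compound 1 to compound 3 (within the scatter), fall inside the scatter, as does a number 7 percentage points higher from compound 2 to compound 3 (within the scatter), so the three compounds cannot be told apart on these data.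

The step to compound 4 `COc1ccc(Nc2ccc3c(c2)C(=O)N(C2CCC(=O)NC2=O)C3=O)cc1` introduces (methoxy in place of hydrogen on an aromatic carbon). The closest measured precedent is the placing of a methyl group on an aromatic carbon, which produced a number 1 percentage points lower from compound 1 to compound 3 (within the scatter), a step inside the scatter. The exchange of methyl(phenyl)amino for (4-methylphenyl)amino, a number 7 percentage points higher from compound 2 to compound 3 (within the scatter), was also inside the scatter. Going by the values given here, nothing here separates any of the three compounds from one another, and there is no measured methoxy compound to draw on.

On these grounds no movement beyond the scatter is expected for compound 4: the estimated step is a number 1 percentage points lower from compound 1 to compound 4 (within the scatter). Compound 4 is therefore expected to show 5% in this assay, within a range of -7% to 17%.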

Compound 4, a percentage reported as inhibition, at one concentration (the size of the read-out at that concentration, not a potency): 29%
The estimate for compound 4 lay 24 percentage points below the measured number; measured number above the stated range.
By their numbers in this assay, from the lowest: compounds 2, 3 and 1 (each within the scatter of the next); then compound 4.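

Methoxy on this aromatic carbon, para to a large group, is the first change here to move the number in this assay beyond the scatter, with a number 23 percentage points higher from compound 1 to compound 4 (beyond the scatter) as its step, whereas methyl on the same carbon left compound 3 within the scatter of compound 1. The gain therefore depends on which group fills the position and does not follow from any substituent there: methoxy in place of methyl gives a number 24 percentage points higher from compound 3 to compound 4 (beyond the scatter) on its own, and the exchange that also frees the nitrogen of its methyl gives a number 31 percentage points higher from compound 2 to compound 4 (beyond the scatter) as the largest step in the set. Nothing available bears on why methoxy behaves differently from methyl here.

The compounds shown carry methoxy on one ring carbon only, so they leave open whether the same group would raise the number from another carbon of that ring. They also leave open how ethoxy, hydroxy, fluorine or an amine on this carbon would read, and whether methoxy would have the same effect with the methyl kept on the nitrogen.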